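The source may report more compounds than this note shows. Statements on the series, on what has been measured and on what is new or still open speak of the compounds shown alone.

Compound 1, `CCCCCCCCCCCCC/C=C/[C@@H](O)[C@H](COC(=O)NCCN(C)C)NC(=O)C(C)(C)C`, in an assay on membranes from brain for inhibition of sphingomyelin phosphodiesterase 2 (Rattus norvegicus), using microsomes; a lower number here means a stronger inhibitor, a higher number a weaker inhibitor: 4100 nM
Compound 2, `CCCCCCCCCCCCC/C=C/[C@@H](O)[C@H](COC(=O)Nc1ccccn1)NC(=O)C(C)(C)C`, in this assay: 7900 nM
Compound 3, `CCCCCCCCCCCCC/C=C/[C@@H](O)[C@H](COC(=O)NCc1cccnc1)NC(=O)C(C)(C)C`, in this assay: 2100 nM

Among these three, compound 3 gives the lowest number in this assay. Its nearest neighbour is compound 1, separated by a 2.0-fold lower number from compound 1 to compound 3 (0.29 log units; within the scatter), which leaves the two indistinguishable. Compound 2 stands further off, with a 3.8-fold lower number from compound 2 to compound 3 (0.58 log units; beyond the scatter), and that gap is real. Between compound 1 and compound 2 the difference is a 1.9-fold higher number from compound 1 to compound 2 (0.28 log units; within the scatter), again not separable.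

Compound 4, `CCCCCCCCCCCCC/C=C/[C@@H](O)[C@H](COC(=O)NCc1ccc(N(C)C)cc1)NC(=O)C(C)(C)C`, has not yet been measured. It differs from compound 3 in one place: 4-(dimethylamino)phenyl in place of pyridin-3-yl on a saturated chain carbon bound to an amide-type nitrogen. Among the compounds with values here, no measured pair swaps an aromatic ring for another aromatic ring on that saturated chain carbon, so nothing bears directly on this change. The steps that come closest are those touching the same position: from compound 1 to compound 3 the change was a 2.0-fold lower number from compound 1 to compound 3 (0.29 log units; within the scatter), and from compound 2 to compound 3 it was a 3.8-fold lower number from compound 2 to compound 3 (0.58 log units; beyond the scatter). Those two steps are small to modest, and all three compounds sit within a narrow band, so a step of comparable size, in either direction or none beyond the scatter, is expected here.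

On that basis compound 4 is estimated at 2500 nM, with a range from 900 nM to 7000 nM, which corresponds to an expected step of a 1.2-fold higher number from compound 3 to compound 4 (0.08 log units; within the scatter).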

Compound 4, half-maximal inhibitory concentration: 8200 nM
For compound 4 the middle estimate is 3.3-fold (0.52 log units) below the measured one, outside the stated range (above it).
By their numbers in this assay, from the lowest: compounds 3, 1, 2 and 4 (each within the scatter of the next, the first and the last beyond it).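

In this assay, within the data shown here, the exchange of pyridin-3-yl for 4-(dimethylamino)phenyl on a saturated chain carbon bound to an amide-type nitrogen gives a step beyond the scatter (a 3.9-fold higher number from compound 3 to compound 4 (0.59 log units; beyond the scatter)), so this position responds when one aromatic ring replaces another, a kind of change that no earlier pair covered. The step is of a size with the earlier gap between the pyridin-2-yl and (pyridin-3-yl)methyl carbamates (a 3.8-fold lower number from compound 2 to compound 3 (0.58 log units; beyond the scatter)), while the new compound cannot be separated from the other two (a 1.0-fold higher number from compound 2 to compound 4 (0.02 log units; within the scatter); a 2.0-fold higher number from compound 1 to compound 4 (0.30 log units; within the scatter)), so the advantage of compound 3 over it is modest and does not extend to a clear order among the rest. Nothing available accounts for the step.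

Going by these compounds, whether the higher number goes with the dimethylamino group or with the exchange of a ring holding a nitrogen for a ring of carbon only remains open. On these data alone, a plain benzyl group, a 4-methoxybenzyl group or a (pyridin-4-yl)methyl group on the same amide-type nitrogen would bear on that question, and what each of them gives here remains unknown.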